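The compounds below may be only part of what the source reports. "The series", "measured", "known", "first", "only" and "open" are said of these compounds alone.

In an assay on HEK293 cells for inhibition of N-acylethanolamine-hydrolyzing acid amidase (Rattus norvegicus), read by LC-MS, with a stated time of 30 min (a higher number here means a weaker inhibitor, a lower number a stronger inhibitor), compound 1 `O=C(CCc1ccc(-c2cccc(F)c2)cc1)N1CCCC1` gives 1800 nM, the lowest of the two numbers recorded; compound 2 `COc1ccc(CCCCCCC(=O)N2CCCC2)cc1` gives 35400 nM. Compound 3 `O=C(O)c1ccc(CCCCCCC(=O)N2CCCC2)cc1` is recorded only as a limit of the assay, > 100000 nM. Among the measured compounds shown here, the single measured step between compounds that differ in one place is an at least 2.8-fold higher number from compound 2 to compound 3 (0.45 log units; beyond the scatter); its size is known only as a minimum, since it rests on (the limit of > 100000 nM in this assay, at which 1 of the 3 values shown sits). Compound 4 `O=C(CCc1ccc(OC2CCCCC2)cc1)N1CCCC1` is not yet measured in this assay. It differs from compound 1 in one place: cyclohexyloxy in place of 3-fluorophenyl on an aromatic carbon. For the measured compounds named here, the measured step concerns carboxy in place of methoxy on the longer-chain pair and does not bear on this exchange, so no measured step informs it. An aromatic ring leaves and a non-aromatic ring carrying one hydrogen-bond acceptor enters, with no change of charge. With nothing to lean on, the expectation is a number near that of compound 1, within the usual scatter or a little beyond it in either direction. Compound 4 is therefore estimated at 2000 nM, with a range of 500 nM to 8000 nM. The step that this estimate means, a 1.1-fold higher number from compound 1 to compound 4 (0.05 log units; within the scatter), is expected to fall within the scatter, with no particular direction.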

Compound 4, half-maximal inhibitory concentration: 700 nM
Compound 4: the middle estimate sits 2.9-fold (0.46 log units) above what was measured; the range from low to high includes it.
By their numbers in this assay, from the lowest: compound 4; then compound 1; then compound 2. At a limit, above all of these: compound 3.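

In this assay putting cyclohexyloxy in place of 3-fluorophenyl on an aromatic carbon gives a 2.6-fold lower number from compound 1 to compound 4 (0.41 log units; beyond the scatter), so in this pair an aromatic ring is not needed at this place for the number to stay low. The only other step shown, carboxy in place of methoxy on the longer-chain pair, runs to a higher number and does not concern a ring-bearing group, so this pair gives the only reading of such an exchange on the core of compound 1. Nothing measured here bears on why the number falls with this exchange.

The compounds shown do not separate the non-aromatic ring from the oxygen that joins it, and a cyclohexyl group set directly on the aromatic carbon or a phenoxy group at the same place would pull these two apart. Also open, as far as these compounds go, are an amine or a carboxylic acid on the cyclohexyloxy ring, and whether the same exchange holds with the longer chain of compound 2.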